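Swapping the pyridine ring for a thiophene on the shared core

The source may hold more compounds than are shown below. What is called first, only, known or untested is meant among the compounds shown, and "the series" means these compounds.

The measured compounds:
Compound 1, `Cc1cc(C#N)cc(C)c1Oc1nc(Nc2ccc(C#N)cc2)ncc1-c1cccs1`: 6430 nM
Compound 2, `Cc1cc(C#N)cc(C)c1Oc1nc(Nc2ccc(C#N)cc2)ncc1-c1ccncc1`: 28000 nM
Compound 3, `Cc1cc(C)cc(-c2cnc(Nc3ccc(C#N)cc3)nc2Oc2c(C)cc(C#N)cc2C)c1`: 39000 nM

Three compounds share one core and differ only in the aromatic group on the core. In an ADME assay on MT4 cells (Homo sapiens) for cytotoxicity, read by MTT assay, with a stated time of 5 days (on this read-out higher numbers stand for lower toxicity in this test and lower numbers for higher toxicity in this test), compound 2 stands second highest of the three numbers, with compound 3 nearest and compound 1 furthest away. The step of a 4.4-fold higher number from compound 1 to compound 2 (0.64 log units; beyond the scatter) lies beyond the scatter, as does a 6.1-fold higher number from compound 1 to compound 3 (0.78 log units; beyond the scatter), whereas a 1.4-fold higher number from compound 2 to compound 3 (0.14 log units; within the scatter) stays within it. The next compound, compound 4, `Cc1cc(C#N)cc(C)c1Oc1nc(Nc2ccc(C#N)cc2)ncc1-c1ccsc1`, has not yet been measured in this assay. It differs from compound 2 by thiophen-3-yl in place of pyridin-4-yl on an aromatic carbon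

Within the data shown here, the one step that bears on this change is the one between compound 1 and compound 2, a thiophene replaced by the pyridine; reversed, it points toward a lower number when a thiophene returns. Compound 4 carries thiophen-3-yl rather than thiophen-2-yl, so the isomer is new and its effect is not known from these data. Compound 4 is therefore expected to give roughly 8000 nM in this assay, within 3000 nM to 25000 nM, meaning a step of about a 3.5-fold lower number from compound 2 to compound 4 (0.54 log units; beyond the scatter) is expected.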

Compound 4, half-maximal cytotoxic concentration: 3920 nM
Compound 4: middle estimate off by 2.0-fold (0.31 log units), on the high side; low and high end bracket the measured number.
By their numbers in this assay, from the lowest: compounds 4 and 1 (each within the scatter of the next); then compounds 2 and 3 (each within the scatter of the next).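

In this assay the thiophen-3-yl group gives a 7.1-fold lower number from compound 2 to compound 4 (0.85 log units; beyond the scatter) and a 9.9-fold lower number from compound 3 to compound 4 (1.00 log units; beyond the scatter) as well, so the low numbers at this position are not confined to thiophen-2-yl. The attachment point on the thiophene has no readable effect, since a 1.6-fold lower number from compound 1 to compound 4 (0.21 log units; within the scatter) stays within the scatter, and compounds 1 and 4 therefore sit together below compounds 2 and 3. Nothing given here explains why the thiophene compounds give lower numbers than compounds 2 and 3.

As far as these compounds go, it remains open whether these low numbers belong to thiophene alone or extend to other five-membered aromatic rings such as furan or thiazole. From the compounds shown here alone, it is also open how the numbers would respond to an amine or a carboxylic acid on the ring at this position.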